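The source may report more compounds than this note shows. Statements on the series, on what has been measured and on what is new or still open speak of the compounds shown alone.

The measured compounds:

Compound 1, `CCN(CC)c1ccc2cc(C(=O)NCCO)c(=O)oc2c1`. In a functional assay on HCT-116 cells (Homo sapiens) for cytotoxicity, read by MTT assay, with a stated time of 72 h (on this read-out higher numbers stand for weaker inhibition and lower numbers for stronger inhibition), compound 1 reaches only the limit > 100000 nM.

Compound 2, `O=C(NCCNC(=O)c1cc2ccc(OCc3ccccc3)cc2oc1=O)c1cc2ccc(OCc3ccccc3)cc2oc1=O`. In this assay compound 2 gives 15900 nM.

Compound 3, `CCN(CC)c1ccc2cc(C(=O)NC(C)C)c(=O)oc2c1`. In this assay compound 3 reaches only the limit > 100000 nM.

Compound 3 therefore stands not at a number but at a limit, the same limit that the limit of > 100000 nM in this assay, at which 2 of the 3 values shown sit, describes. Among the measured compounds shown here, the one measured step that touches the core of compound 3, a step that the two limits leave unreadable from compound 1 to compound 3, runs between two limits and cannot be read in size or direction. Compound 4, `CCN(CC)c1ccc2cc(C(=O)NC3CC3)c(=O)oc2c1`, differs from compound 3 in a single place: cyclopropyl in place of isopropyl on an amide-type nitrogen. For the measured compounds named here, no measured step involves a cyclopropyl group, and the only comparison on the shared core gives no readable size, so there is no basis for expecting a step beyond the scatter in this assay in either direction. The step that this estimate means is expected to be a step that the limit leaves unreadable from compound 3 to compound 4. For compound 4 the estimate in this assay is 120000 nM, within a range from 40000 nM to 400000 nM, most likely reported again only as a limit.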

Compound 4, half-maximal inhibitory concentration: > 100000 nM
Compound 4 gave a limit, no number (the forecaster's own chance of this, stated with the estimate: 80%); the middle value is on the limit's open side.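

In this assay, among the compounds shown here, compound 1, compound 3 and compound 4 each give only a limit, not a number, so no step among them can be read. From the compounds shown here alone, whether 2-hydroxyethyl, isopropyl or cyclopropyl on the amide-type nitrogen makes any difference on this shared core stays open.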